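From Chloro to Acetyl on the Amide Aryl Ring

The source may hold more compounds than are shown below. What is called first, only, known or untested is meant among the compounds shown, and "the series" means these compounds.

Compound 1, `Cc1cccc(C)c1NC(=O)CSc1nnc(-c2ccoc2C)n1Cc1ccco1`, in a functional assay on CHO cells for antagonist activity at Orexin receptor type 2 (Homo sapiens), read by FLIPR and calcium flux (a lower number here means a stronger inhibitor, a higher number a weaker inhibitor), reaches only the limit of the assay, > 15800 nM.
Compound 2, `Cc1occc1-c1nnc(SCC(=O)Nc2ccc(F)cc2)n1Cc1ccco1`, gives 158 nM.
Compound 3, `Cc1occc1-c1nnc(SCC(=O)Nc2cccc(Cl)c2)n1Cc1ccco1`, gives 63.1 nM.

Compound 3 holds the lowest of the two actual numbers, with compound 2 a modest distance above it: a 2.5-fold lower number from compound 2 to compound 3 (0.40 log units; beyond the scatter). The steps away from compound 1 were large, an at least 100-fold lower number from compound 1 to compound 2 (2.00 log units; beyond the scatter) and an at least 250-fold lower number from compound 1 to compound 3 (2.39 log units; beyond the scatter). Compound 4, `CC(=O)c1ccc(NC(=O)CSc2nnc(-c3ccoc3C)n2Cc2ccco2)cc1`, differs from compound 3 in one place: 4-acetylphenyl in place of 3-chlorophenyl on an amide-type nitrogen. For the measured compounds named here, no measured step introduces a 4-acetylphenyl, so the only guide is that changing the aryl group shifted the number modestly, as a 2.5-fold lower number from compound 2 to compound 3 (0.40 log units; beyond the scatter) shows. Compound 4 is therefore expected to give a modestly higher number, a 3.2-fold higher number from compound 3 to compound 4 (0.50 log units; beyond the scatter), estimated at 200 nM, within 40 nM to 1000 nM.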

Compound 4, inhibition constant: 31.6 nM
Beside the measured number, compound 4's estimate is 6.3-fold (0.80 log units) above it, outside the stated range (below it).
By their numbers in this assay, from the lowest: compounds 4 and 3 (each within the scatter of the next); then compound 2. At a limit, above all of these: compound 1.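

A step of a 2.0-fold lower number from compound 3 to compound 4 (0.30 log units; within the scatter) shows that 4-acetylphenyl, with its one hydrogen-bond acceptor, serves on the amide-type nitrogen as well as 3-chlorophenyl does in this assay. Acetyl in place of fluoro on the aromatic carbon counts for more, a step of a 5.0-fold lower number from compound 2 to compound 4 (0.70 log units; beyond the scatter), so the group carried on this aryl ring can shift the number beyond the scatter. The step of an at least 500-fold lower number from compound 1 to compound 4 (2.69 log units; beyond the scatter) rests on a limit for compound 1, not on a number: the limit of > 15800 nM in this assay, at which 1 of the 4 values shown sits.

From the compounds shown here alone, whether the acetyl carbonyl itself matters remains open. So does how an amine or a carboxylic acid in its place would read in this assay.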